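This account rests on a few compounds, and the source may have more. Where it says the series, first, only, none or still open, it means among the compounds named here.

Measured so far:
Compound 1 `CC1CCCCC1C(=O)N1CC(c2nc(-c3cccc(F)c3)no2)C1` – in an assay on HEK293 cells for negative allosteric modulation of metabotropic glutamate receptor 5 (Homo sapiens), read by FLIPR (a higher number here means a weaker inhibitor, a lower number a stronger inhibitor), compound 1 gives > 10000 nM, a limit of the assay.
Compound 2 `CC1CCC(C(=O)N2CC(c3nc(-c4cccc(Cl)c4)no3)C2)CC1` – compound 2 gives > 10000 nM, again a limit.
Compound 3 `O=C(c1ccc(F)c(F)c1)N1CC(c2nc(-c3cccc(F)c3)no2)C1` – compound 3 gives > 10000 nM, also a limit.

Going by the values given here, compound 2 stands at the limit of > 10000 nM in this assay, at which 3 of the 3 values shown sit, so it cannot be placed above or below the other two, and the only step between measured compounds, a step that the two limits leave unreadable from compound 1 to compound 3, cannot be sized either. Compound 4 `COC1CCN(C(=O)N2CC(c3nc(-c4cccc(Cl)c4)no3)C2)CC1` differs from compound 2 by 4-methoxypiperidin-1-yl in place of 4-methylcyclohexyl on a carbonyl carbon. Among the compounds with values here, no measured step bears on this change, and with compound 2 itself at a limit the step from compound 2 to compound 4 cannot be expected to show a readable direction. Compound 4 is therefore estimated at 15000 nM, with a range from 4000 nM to 60000 nM, with the estimated step that the limit leaves unreadable from compound 2 to compound 4 most likely leaving compound 4 at the same limit.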

Compound 4, half-maximal inhibitory concentration: > 10000 nM
Compound 4: no number, only a limit; the forecaster's own chance of this, stated with the estimate: 80%; the middle value lies beyond the limit too.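

Going by these compounds alone, compound 2 and compound 4 both give only a limit of the assay, and no step between them can be read. The compounds shown leave open which group on the carbonyl carbon, if any, would give a readable value in this assay at all.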